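Swapping One Fluorinated Group in a Weak Inhibitor

The source may hold more compounds than are shown below. What is called first, only, known or untested is meant among the compounds shown, and "the series" means these compounds.

In a functional assay on VCaP cells (Homo sapiens) for antiproliferative activity, read by propidium iodide staining, with a stated time of 96 h (a lower number here means a stronger inhibitor, a higher number a weaker inhibitor), compound 1 `CC(O)(COc1ccc(S(F)(F)(F)(F)F)cc1)C(=O)Nc1ccc(S(F)(F)(F)(F)F)cc1` gives 9300 nM, while compound 2 `CC(O)(CS(=O)(=O)c1cccc(S(F)(F)(F)(F)F)c1)C(=O)Nc1cccc(S(F)(F)(F)(F)F)c1` gives 19000 nM. Compound 2 therefore has the higher number of the two and is the weaker inhibitor, by a gap just beyond the usual scatter. Compound 3 `CC(O)(CS(=O)(=O)c1cccc(C(F)(F)F)c1)C(=O)Nc1cccc(S(F)(F)(F)(F)F)c1` differs from compound 2 in one place: a group of 4 heavy atoms (1 carbon, 3 fluorine; no ring) in place of a group of 6 heavy atoms (5 fluorine, 1 sulfur; no ring), on an aromatic carbon. The incoming group is a trifluoromethyl, placed on an aromatic carbon where the larger fluorine-and-sulfur group stood. Among the compounds with values here, no measured pair shows this swap on its own, so the data offer no direct guide, and only a small change is expected. The estimated step is a 1.3-fold lower number from compound 2 to compound 3 (0.10 log units; within the scatter), slightly towards a lower number and within the usual scatter. In this assay the estimate for compound 3 is 15000 nM, with an expected range from 6000 nM to 40000 nM.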

Compound 3, half-maximal inhibitory concentration: 35500 nM
Beside the measured number, compound 3's estimate is 2.4-fold (0.37 log units) below it; the measured number falls inside the stated range.
By their numbers in this assay, from the lowest: compound 1; then compounds 2 and 3 (each within the scatter of the next).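

Within the data shown here, this pair gives the first direct reading of the swap: with trifluoromethyl in place of the group of five fluorines and one sulfur on this aromatic carbon, this assay shows a 1.9-fold higher number from compound 2 to compound 3 (0.27 log units; within the scatter). The two compounds therefore cannot be told apart in this assay, even though the incoming group has fewer heavy atoms than the one it replaces. At this position, this single swap shows no effect larger than the ordinary variation between repeated measurements. No measurement in hand bears on why the two groups read alike here.

As far as these compounds go, whether this position tolerates other kinds of group remains open, since an amine, a carboxylic acid or a longer chain there could give a quite different number. The same swap on the group shared by compound 2 and compound 3, on the amide side, also remains untested in the compounds shown.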